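From Cyano to Hydrogen: Estimating Compound 4

The compounds below may be only part of what the source reports. "The series", "measured", "known", "first", "only" and "open" are said of these compounds alone.

Compound 1, `COc1cccc(C#Cc2csc(Cl)n2)c1`, gives 8.1 nM in an assay on brain for displacement of a labelled ligand from metabotropic glutamate receptor 5 (Rattus norvegicus); a higher number here means a weaker inhibitor, a lower number a stronger inhibitor.
Compound 2, `COc1cccc(C#Cc2csc(F)n2)c1`, gives 22.7 nM in this assay.
Compound 3, `N#Cc1cccc(C#Cc2csc(F)n2)c1`, gives 1.6 nM in this assay.

Compound 3 stands at the lowest number of the three in this assay, with its steps to both other compounds beyond the scatter, so on these numbers it is the strongest inhibitor of the set. Two single-point steps are known. Going from compound 1 to compound 2 gave a 2.8-fold higher number from compound 1 to compound 2 (0.45 log units; beyond the scatter), a modest shift for fluoro in place of chloro. Going from compound 2 to compound 3 gave a 14-fold lower number from compound 2 to compound 3 (1.15 log units; beyond the scatter), a large shift for cyano in place of methoxy.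

Compound 4, `Fc1nc(C#Cc2ccccc2)cs1`, differs from compound 3 by hydrogen in place of cyano on an aromatic carbon. For the measured compounds named here, no measured step removes a group outright; the nearest guide is the step from compound 2 to compound 3, which shows that what sits at this place matters strongly, since exchanging methoxy for cyano moved the number by a 14-fold lower number from compound 2 to compound 3 (1.15 log units; beyond the scatter). Because the step from compound 2 to compound 3 gave a 14-fold lower number from compound 2 to compound 3 (1.15 log units; beyond the scatter) when cyano entered in place of methoxy, and now the cyano is taken away and nothing but hydrogen enters, compound 4 is expected to give a higher number than compound 3, by a step estimated at a 7.5-fold higher number from compound 3 to compound 4 (0.88 log units; beyond the scatter). For compound 4 the estimate is 12 nM, with a range from 3 nM to 50 nM.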

Compound 4, inhibition constant: 122 nM
Compound 4: the middle estimate sits 10-fold (1.01 log units) below what was measured, and the stated range ends below it.
By their numbers in this assay, from the lowest: compound 3; then compound 1; then compound 2; then compound 4.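

Taking the cyano away from the aromatic carbon of the six-membered aromatic ring of carbon only gave a 76-fold higher number from compound 3 to compound 4 (1.88 log units; beyond the scatter) in this assay, a larger shift than the exchange of methoxy for cyano had shown at this place. Hydrogen in place of methoxy also gave a 5.4-fold higher number from compound 2 to compound 4 (0.73 log units; beyond the scatter), so with fluoro held constant, both substituents give lower numbers than hydrogen, and the earlier compounds could not show that methoxy, the poorer of those two groups, still gives a stronger inhibitor than the unsubstituted ring. Among these three compounds the order at this place runs from cyano through methoxy to hydrogen, but no measurement offered here accounts for that order.

With only three groups compared at this place, the compounds shown leave open whether the order reflects something shared by cyano and methoxy or two unrelated contributions, and how groups such as an amine, a carboxylic acid or a methyl would fall. They also pair chloro only with methoxy, so whether the loss on going to hydrogen carries over when chloro replaces fluoro remains an open question.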